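This account rests on a few compounds, and the source may have more. Where it says the series, first, only, none or still open, it means among the compounds named here.

In a functional assay on A498 cells (Homo sapiens) for cytotoxicity (a higher number here means a weaker inhibitor of growth, a lower number a stronger inhibitor of growth), compound 3 (`CSc1ccc(C2=C(c3ccc(O)cc3)C(=O)N3CCCC3C2)cc1`) gives > 100000 nM, which is a limit of the assay and not a number. That makes it the weakest of the three measured compounds. Compound 1 (`CSc1ccc(C2=C(c3ccc(F)c(C)c3)C(=O)N3CCCC3C2)cc1`) gives 300 nM, and compound 2 (`COc1ccc(C2=C(c3ccc(SC)cc3)CC3CCCN3C2=O)cc1`) gives 800 nM.

Compound 4 (`CSc1ccc(C2=C(c3ccc(OCC4CO4)cc3)C(=O)N3CCCC3C2)cc1`) keeps the rest of compound 3 but has (oxiran-2-yl)methyl in place of hydrogen on an oxygen on an aromatic ring, so hydroxy becomes (oxiran-2-yl)methoxy: (oxiran-2-yl)methyl in place of hydrogen on an oxygen on an aromatic ring.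

The closest measured change happens on the same oxygen, with hydrogen in place of methyl, and it gives an at least 120-fold higher number from compound 2 to compound 3 (2.09 log units; beyond the scatter). Read in reverse, this suggests that putting a group on that oxygen can restore growth inhibition. The step of an at least 330-fold higher number from compound 1 to compound 3 (2.52 log units; beyond the scatter) is also large, but it exchanges the whole aromatic substituent, so it bears on the question less directly. Within the data shown here, no measured compound carries the (oxiran-2-yl)methyl group, so the size remains uncertain, though a large move to a lower number is expected in this assay. The estimated step is an at least 66-fold lower number from compound 3 to compound 4 (1.82 log units; beyond the scatter). For compound 4 the expected value is 1500 nM, with an estimated range of 200 nM to 15000 nM.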

Compound 4, concentration for 50% growth inhibition: 500 nM
Beside the measured number, compound 4's estimate is 3.0-fold (0.48 log units) above it, within the range that was stated.
By their numbers in this assay, from the lowest: compounds 1, 4 and 2 (each within the scatter of the next, the first and the last beyond it). At a limit, above all of these: compound 3.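

In this assay, putting (oxiran-2-yl)methyl on the oxygen in place of hydrogen gives an at least 200-fold lower number from compound 3 to compound 4 (2.30 log units; beyond the scatter), so the recovery of growth inhibition seen with methyl on this oxygen is not unique to methyl. Adding the oxiran-2-yl group to that methyl carbon changes little, with a 1.6-fold lower number from compound 2 to compound 4 (0.20 log units; within the scatter), which shows that this larger group on the oxygen is tolerated in this assay. Compound 3 sits at a limit and not at a number, so the first of these steps gives only a minimum size: the limit of > 100000 nM in this assay, at which 1 of the 4 values shown sits.

The compounds shown leave open whether the three-membered ring itself matters, or whether an open-chain group such as propyl would serve equally well. They also leave open how a longer chain ending in an amine or a carboxylic acid would fare on this oxygen.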